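Replacing 4-Chlorophenyl with Trifluoromethyl

The source may hold more compounds than are shown below. What is called first, only, known or untested is meant among the compounds shown, and "the series" means these compounds.

In a functional assay on T47D cells (Homo sapiens) for inhibition, read by sulforhodamine B assay, with a stated time of 48 h, tested at 10 uM (a higher number here means more inhibition of growth at the concentration tested, a lower number less inhibition of growth), compound 1 `CC(=O)c1ccc(NC(=O)Cn2nc(-c3ccc(Cl)cc3)nc2N)cc1` gives 21.6% while compound 2 `C/C(=N\O)c1ccc(NC(=O)Cn2nc(-c3ccc(Cl)cc3)nc2N)cc1` gives 13.5% and compound 3 `COc1cc(-c2nc3sc(-c4ccccc4)cn3n2)cc(OC)c1OC` gives 55% in the same test. This places compound 1 level with compound 2 and far under compound 3. In compound 4 `CC(=O)c1ccc(NC(=O)Cn2nc(C(F)(F)F)nc2N)cc1` the change from compound 1 is trifluoromethyl in place of 4-chlorophenyl on an aromatic carbon and it sits on the shared core. Among the measured compounds shown here, the one measured step of a number 8.1 percentage points lower from compound 1 to compound 2 (within the scatter) touches another part of the molecule and stays within the scatter, so no measured pair tests this swap directly. A modest fall in this assay is expected, not beyond the scatter, with the estimated step of a number 6.6 percentage points lower from compound 1 to compound 4 (within the scatter) as the best guess. Compound 4 is estimated at 15% with a likely range from 2% to 30% in this measurement.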

Compound 4, percent growth inhibition at one concentration: 10.8%
Compound 4: the middle estimate sits 4.2 percentage points above what was measured; the measured number falls inside the stated range.
By their numbers in this assay, from the lowest: compounds 4, 2 and 1 (each within the scatter of the next, the first and the last beyond it); then compound 3.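

In this assay the step of a number 10.8 percentage points lower from compound 1 to compound 4 (beyond the scatter) is the only one shown that lies beyond the scatter, so this position on the shared core responds to a change of group. Trading the ring-bearing 4-chlorophenyl for the ring-free trifluoromethyl costs some growth inhibition, though only a modest amount. Nothing available explains this loss. Still open, on these data alone, is how other groups on this aromatic carbon would compare, such as an amine, a carboxylic acid or a longer carbon chain. As far as these compounds go, whether a plain phenyl ring would match 4-chlorophenyl also remains unknown.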